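A few compounds are considered here, and "the series" means these few. Any claim that something is new, unique, unknown or untested is made for them only; others in the source may bear on it.

Working notes on the series, which shares one fused core and varies the aryl group on the five-membered aromatic ring. Compound 1 `Fc1ccc(-c2cn3nc(Cc4ccc(Cl)cc4)sc3n2)cc1` in a functional assay on L1210 cells (Mus musculus) for cytotoxicity, with a stated time of 48 h (a higher number here means a weaker inhibitor, a lower number a stronger inhibitor), gives > 250000 nM, which is a limit of the assay and not a number. Compound 2 `Cc1ccc(-c2cn3nc(Cc4ccc(Cl)cc4)sc3n2)cc1` in this assay gives > 250000 nM, again a limit. Within the data shown here, compound 3 `Clc1ccc(Cc2nn3cc(-c4ccc(Cl)cc4Cl)nc3s2)cc1` in this assay gives 247000 nM, the only number among the three values shown. The step that the two limits leave unreadable from compound 1 to compound 2 cannot be read. The steps of an at least 1.0-fold lower number from compound 1 to compound 3 (0.00 log units; that floor lies within the scatter) and an at least 1.0-fold lower number from compound 2 to compound 3 (0.00 log units; that floor lies within the scatter) are floors that lie within the scatter, since the limit of > 250000 nM in this assay, at which 2 of the 3 values shown sit, caps what can be seen for compounds 1 and 2. Compound 4 `Clc1ccc(Cc2nn3cc(-c4ccccc4)nc3s2)cc1` differs from compound 3 by phenyl in place of 2,4-dichlorophenyl on an aromatic carbon. Among the measured compounds shown here, no measured step in this set reaches beyond the scatter, so the step expected in this assay is a 1.0-fold higher number from compound 3 to compound 4 (0.01 log units; within the scatter), nothing beyond the scatter. Compound 4 is therefore estimated at 250000 nM in this assay, with a range from 100000 nM to 600000 nM, and a limit rather than a number is the more likely report.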

Compound 4, half-maximal inhibitory concentration: > 250000 nM
Compound 4 gave a limit, no number; the forecaster's own chance of this, stated with the estimate: 65%; the middle value lies on the limit itself.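

Replacing 2,4-dichlorophenyl with phenyl on this aromatic carbon gives an at least 1.0-fold higher number from compound 3 to compound 4 (0.00 log units; that floor lies within the scatter). This adds the unsubstituted phenyl to the groups seen at this position, and the loss of both chlorine atoms opens no readable difference in this assay: the limit of > 250000 nM in this assay, at which 3 of the 4 values shown sit. The steps linking compound 4 to compound 1 and to compound 2 join two limits and cannot be read.

On these data alone, what an amine or a carboxylic acid on the phenyl ring would do at this position stays open, as does whether any group here can bring the number into a clearly readable range in this assay. The compounds shown also leave open how a change elsewhere on the shared core, away from this aryl group, would read in the same cells.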